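Swapping morpholin-4-yl for 3,4-dimethylpiperazin-1-yl

The source may report more compounds than this note shows. Statements on the series, on what has been measured and on what is new or still open speak of the compounds shown alone.

Measured so far in an ADME assay on microsomes from liver (Mus musculus) for metabolic stability, read by LC-MS, with a stated time of 30 min, tested at 1 uM; on this read-out higher numbers stand for a more stable compound and lower numbers for a less stable compound:
- compound 1 `CC[C@@H]1CC[C@@H](C(=O)N2CCN(C)CC2)N1C(=O)C1=C(C(C)C)N2C(=N[C@@](C)(c3ccc(Cl)cc3)[C@H]2c2ccc(Cl)cc2)S1` gives 50% 
- compound 2 `CC[C@@H]1CC[C@@H](C(=O)N2CCOCC2)N1C(=O)C1=C(C(C)C)N2C(=N[C@@](C)(c3ccc(Cl)cc3)[C@H]2c2ccc(Cl)cc2)S1` gives 6% 

Compound 2 holds the lower of these two numbers, and its gap to compound 1 lies beyond the usual scatter. Compound 3 `CC[C@@H]1CC[C@@H](C(=O)N2CCN(C)[C@@H](C)C2)N1C(=O)C1=C(C(C)C)N2C(=N[C@@](C)(c3ccc(Cl)cc3)[C@H]2c2ccc(Cl)cc2)S1` keeps the shared core of compound 2 and alters a single group. The change is 3,4-dimethylpiperazin-1-yl in place of morpholin-4-yl on a carbonyl carbon and, in words, 3,4-dimethylpiperazin-1-yl stands in place of morpholin-4-yl on a carbonyl carbon. Among the compounds with values here, one measured step bears on this: a number 44 percentage points lower from compound 1 to compound 2 (beyond the scatter) with morpholin-4-yl in place of 4-methylpiperazin-1-yl at that same carbonyl carbon. That step was large. Within the data shown here, compound 3 leaves morpholin-4-yl behind again, although its new group is not identical to 4-methylpiperazin-1-yl, and no measured compound shows what that difference does. A large rise, beyond the scatter, is therefore expected, somewhat smaller than the measured drop. The expected step is a number 39 percentage points higher from compound 2 to compound 3 (beyond the scatter) in this assay on this estimate. The estimate for compound 3 is 45% with an expected range from 25% to 65% in this measurement.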

Compound 3, percent of the compound remaining: 69%
Compound 3: the middle estimate sits 24 percentage points below what was measured, and the stated range ends below it.
By their numbers in this assay, from the lowest: compound 2; then compound 1; then compound 3.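

In this assay, moving away from morpholin-4-yl on this carbonyl carbon does more than restore the earlier level, giving a number 63 percentage points higher from compound 2 to compound 3 (beyond the scatter). The new information lies in the comparison with the 4-methylpiperazin-1-yl compound: with methyl in place of hydrogen on a saturated ring carbon, the result is a number 19 percentage points higher from compound 1 to compound 3 (beyond the scatter), so even this small addition to the piperazine ring moves the read-out by more than the usual scatter. Among these three compounds, then, the number depends both on which ring sits on the carbonyl carbon and on how that ring is substituted, though nothing available explains why these changes have these effects.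

From the compounds shown here alone, it remains open whether a larger group on the same ring carbon, such as ethyl, would raise the number further, or whether an unsubstituted piperazin-1-yl would lower it. The role of the defined stereocentre also remains open, as the opposite arrangement of the added methyl does not appear among these compounds.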